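This account rests on a few compounds, and the source may have more. Where it says the series, first, only, none or still open, it means among the compounds named here.

Measured so far:
- compound 1 `NC(=O)c1c(NC(=O)c2ccccc2Cl)sc2c1CCN(Cc1c(Cl)cccc1Cl)C2`: in a functional assay on MKN-74 cells (Homo sapiens) for antiproliferative activity, with a stated time of 24 h (a higher number here means a weaker inhibitor, a lower number a stronger inhibitor), compound 1 gives 4740 nM
- compound 2 `Cc1ccc(C(=O)Nc2sc3c(c2C(N)=O)CCN(Cc2c(Cl)cccc2Cl)C3)cc1`: compound 2 gives 12300 nM
- compound 3 `Cc1ccc(C(=O)Nc2sc3c(c2C(N)=O)CCN(Cc2ccc(Cl)cc2Cl)C3)cc1`: compound 3 gives 25500 nM

Compound 3 carries the highest number of the three: a 2.1-fold higher number from compound 2 to compound 3 (0.32 log units; beyond the scatter), and compound 1 sits furthest below it. Compound 4 `NC(=O)c1c(NC(=O)c2cccc([N+](=O)[O-])c2)sc2c1CCN(Cc1ccc(Cl)cc1Cl)C2` differs from compound 3 by 3-nitrophenyl in place of 4-methylphenyl on a carbonyl carbon. For the measured compounds named here, only one measured step touches this carbonyl position, a 2.6-fold higher number from compound 1 to compound 2 (0.41 log units; beyond the scatter), which shows that exchanging the aryl on the carbonyl shifts the number modestly; the 4-methylphenyl came out worse there. Nothing measured speaks to the nitro group itself. A modest step downward from compound 3 to compound 4 is therefore expected, a 2.0-fold lower number from compound 3 to compound 4 (0.29 log units; within the scatter), though a null result within the scatter is nearly as plausible. Compound 4 is estimated at 13000 nM in this assay, with a range of 5000 nM to 35000 nM.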

Compound 4, half-maximal inhibitory concentration: 16500 nM
Compound 4: the middle estimate sits 1.3-fold (0.10 log units) below what was measured, and the stated range covers the measured number.
By their numbers in this assay, from the lowest: compound 1; then compounds 2, 4 and 3 (each within the scatter of the next, the first and the last beyond it).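

In this assay the exchange gives a 1.5-fold lower number from compound 3 to compound 4 (0.19 log units; within the scatter) and so the two aryl groups on this carbonyl carbon cannot be told apart, although the 3-nitrophenyl carries hydrogen-bond acceptors that the 4-methylphenyl lacks. Unlike a 2.6-fold higher number from compound 1 to compound 2 (0.41 log units; beyond the scatter) this exchange stays within the scatter, so not every aryl exchange at this place moves the number. No measurement at hand offers an explanation for this. Still open, going by these compounds, is whether an amine or a carboxylic acid on this phenyl ring would move the number beyond the scatter.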